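A few compounds are considered here, and "the series" means these few. Any claim that something is new, unique, unknown or untested is made for them only; others in the source may bear on it.

Compound 1 `CC(=O)Nc1cccc(NC(=O)COc2ccc3c(=O)ccoc3c2)c1` gives 2500 nM in an assay on isolated protein for inhibition of Rho-associated protein kinase 1 (Homo sapiens), read by scintillation counting, radiometric assay and 33P incorporation, with a stated time of 40 min, in the presence of a further agent that is not named here (on this read-out higher numbers stand for weaker inhibition and lower numbers for stronger inhibition), the highest of the two numbers measured. Compound 2 `O=C(COc1ccc2c(=O)ccoc2c1)Nc1cccc(NC(=O)c2ccc([N+](=O)[O-])cc2)c1` gives 67 nM in this assay, and the step of a 37-fold lower number from compound 1 to compound 2 (1.57 log units; beyond the scatter) came with 4-nitrophenyl in place of methyl on a carbonyl carbon. Compound 3 `COC(=O)c1ccc(C(=O)Nc2cccc(NC(=O)COc3ccc4c(=O)ccoc4c3)c2)cc1` differs from compound 1 by 4-(methoxycarbonyl)phenyl in place of methyl on a carbonyl carbon. Among the compounds with values here, because the only related step was a 37-fold lower number from compound 1 to compound 2 (1.57 log units; beyond the scatter), a large drop is expected here too, though 4-(methoxycarbonyl)phenyl is not 4-nitrophenyl, so a somewhat smaller step a 17-fold lower number from compound 1 to compound 3 (1.22 log units; beyond the scatter) is estimated. Compound 3 is expected to give 150 nM, with a range from 40 nM to 600 nM.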

Compound 3, half-maximal inhibitory concentration: 72 nM
Beside the measured number, compound 3's estimate is 2.1-fold (0.32 log units) above it, within the range that was stated.
By their numbers in this assay, from the lowest: compounds 2 and 3 (each within the scatter of the next); then compound 1.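

The large gain at this carbonyl carbon does not depend on the nitro group: in this assay, 4-(methoxycarbonyl)phenyl in place of methyl brings a 35-fold lower number from compound 1 to compound 3 (1.54 log units; beyond the scatter). Methoxycarbonyl in place of nitro on the aromatic carbon gives a 1.1-fold higher number from compound 2 to compound 3 (0.03 log units; within the scatter), so these numbers cannot tell the two groups apart. Nothing available explains this result.

Still open, from the compounds shown here alone, is whether a plain phenyl ring alone would give the same gain. An amine or a carboxylic acid in place of methoxycarbonyl might also keep the number this low, or might not.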